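Compound 3 to Compound 4: a Swap at the Outer Ring

The source may hold more compounds than are shown below. What is called first, only, known or untested is meant among the compounds shown, and "the series" means these compounds.

Of the compounds shown here, three built on a shared core have been measured in a functional assay for inhibition, with Homo sapiens as the target; on this read-out lower numbers stand for stronger inhibition and higher numbers for weaker inhibition. Compound 1 `Cc1cccc(Nc2nccc(-c3cccs3)n2)c1` gives 300 nM. Compound 2 `Cc1cc(C)cc(Nc2nccc(-c3ccccn3)n2)c1` gives 100 nM. Compound 3 `CC1CCN(c2ccc(Nc3nccc(-c4cccnc4)n3)cc2)CC1` gives 500 nM, the highest of the three numbers; its gap to compound 1 lies within the usual scatter, while its gap to compound 2 lies beyond it. No pair among these three differs in a single place, so no single-point step can be read from them.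

Compound 4 `CC(C)(C)c1ccc(Nc2nccc(-c3cccnc3)n2)cc1` has not yet been measured in this assay. It differs from compound 3 in one place: tert-butyl in place of 4-methylpiperidin-1-yl on an aromatic carbon. The group that enters has no ring and no hydrogen-bond acceptor, and it sits on an aromatic carbon of a six-membered aromatic ring of carbon only, para to a large group.

Going by the values given here, no measured pair shows a change of this kind, and the size of the step is open. The account expects the move from compound 3 to compound 4 to be modest, a 1.3-fold lower number from compound 3 to compound 4 (0.10 log units; within the scatter), with no direction beyond the scatter clearly favoured. Compound 4 is accordingly estimated at 400 nM, with a range from 150 nM to 1200 nM.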

Compound 4, half-maximal inhibitory concentration: 600 nM
Estimate against measurement, compound 4: 1.5-fold (0.18 log units) below; measured number inside the range.
By their numbers in this assay, from the lowest: compound 2; then compounds 1, 3 and 4 (each within the scatter of the next).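

In this assay, going by these compounds alone, the exchange of 4-methylpiperidin-1-yl for tert-butyl, on an aromatic carbon para to a large group, gives a 1.2-fold higher number from compound 3 to compound 4 (0.08 log units; within the scatter), the first step in this set that can be read at a single place. The group that leaves carries a six-membered non-aromatic ring and a hydrogen-bond acceptor, and the group that enters carries neither, yet compound 3 and compound 4 cannot be told apart on this read-out. This one pair therefore gives no sign that either the ring or the acceptor of 4-methylpiperidin-1-yl matters at this position, and no measurement is at hand that would account for the result.

Among the compounds shown, only these two groups can be compared at this place, so it remains open whether a primary amine, a carboxylic acid or a methoxy group there would give a number beyond the scatter. From the compounds shown here alone, it is also open whether the same exchange would read alike with another part of the shared core altered.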